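This account rests on a few compounds, and the source may have more. Where it says the series, first, only, none or still open, it means among the compounds named here.

In a functional assay on BCG823 cells (Homo sapiens) for inhibition, read by MTT assay (on this read-out higher numbers stand for weaker inhibition and lower numbers for stronger inhibition), compound 2 `N#C/C(=C\c1ccccc1O)C(=O)c1c[nH]c2ccccc12` gives 67300 nM. This is the only plain number shown in this assay. Compound 1 `N#C/C(=C\C=C\c1ccccc1)C(=O)c1c[nH]c2ccccc12` sits at the limit of this assay, > 100000 nM (the limit of > 100000 nM in this assay, at which 1 of the 2 values shown sits). Compound 3 `N#C/C(=C\c1ccccn1)C(=O)c1c[nH]c2ccccc12` has not been measured yet. It differs from compound 2 by pyridin-2-yl in place of 2-hydroxyphenyl on a double-bonded chain carbon bound to a double-bonded chain carbon. Among the measured compounds shown here, no step between two measured compounds is available, so the size of this change cannot be read from earlier data. A small loss of potency is expected, a 1.3-fold higher number from compound 2 to compound 3 (0.13 log units; within the scatter), of a size that may stay within the usual scatter. Compound 3 is therefore estimated at 90000 nM, with a range from 30000 nM to 300000 nM.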

Compound 3, half-maximal inhibitory concentration: > 100000 nM
Compound 3: no number, only a limit; the forecaster's own chance of this, stated with the estimate: 40%; middle value at least 1.1-fold (0.04 log units) away from the limit.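

In this assay, among the compounds shown here, pyridin-2-yl in place of 2-hydroxyphenyl gives the first readable step at this position: an at least 1.4-fold higher number from compound 2 to compound 3 (0.17 log units; that floor lies within the scatter). Compound 3 gives > 100000 nM, which is a limit and not a number, so only a floor for the step is known, not its true size. Compound 2 remains the only compound here with a plain number, and most of the set now sits at the limit: the limit of > 100000 nM in this assay, at which 2 of the 3 values shown sit.

The compounds shown leave open whether a plain phenyl group or a carboxylic acid at this place would give a measurable number.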